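The compounds below may be only part of what the source reports. "The series", "measured", "known", "first", "only" and "open" are said of these compounds alone.

Of the compounds shown here, two have so far been measured in an assay on lysate for inhibition of patatin-like phospholipase domain-containing protein 2 (Mus musculus), tested at 200 uM; on this read-out higher numbers stand for more inhibition at the one concentration tested (going by the name of the read-out) and lower numbers for less inhibition. Compound 1 `CCOC(=O)c1cn(-c2ccc(OCC)cc2)nn1` gives 43%, and compound 2 `CCOC(=O)c1cccc(-c2ccc(Br)cc2)c1` gives 34%. Of these two numbers, compound 2 sits at the bottom, but compound 1 lies close enough that the two cannot be told apart on this read-out. The next compound, compound 3 `CCOC(=O)c1cccc(-c2ccc(C(C)=O)cc2)c1`, keeps the core of compound 2 and changes a single group: acetyl in place of bromo on an aromatic carbon. For the measured compounds named here, no pair of measured compounds shows what such a swap does in this assay, so there is no measured step to lean on. Going only by the two numbers shown, a change beyond the scatter is not expected in either direction. The step from compound 2 to compound 3 is expected to be a number 2 percentage points higher from compound 2 to compound 3 (within the scatter). Compound 3 is therefore estimated at 36%, with a range from 15% to 58%.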

Compound 3, a percentage reported as inhibition, at one concentration (the size of the read-out at that concentration, not a potency): 17%
For compound 3 the middle estimate is 19 percentage points above the measured one; the measured number falls inside the stated range.
By their numbers in this assay, from the lowest: compound 3; then compounds 2 and 1 (each within the scatter of the next).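

Acetyl in place of bromo on this aromatic carbon, para to a large group, gives a number 17 percentage points lower from compound 2 to compound 3 (beyond the scatter) in this assay. For the compounds shown here, this is the one measured step so far, and it shows that the group at this position can change the read-out, which the two earlier numbers could not show because those compounds differ in more than one place. The entering acetyl has more heavy atoms than bromo and carries a hydrogen-bond acceptor, but no measurement at hand explains the lower number.

Going by these compounds, one pair cannot separate those differences, so it stays open which of them counts. Methyl, methoxy, an amine or a carboxylic acid at the same position would show whether the lower number goes with the acetyl alone or extends to other groups.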